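Swapping 4-methoxyphenyl for 3-hydroxyphenyl on compound 2

A few compounds are considered here, and "the series" means these few. Any claim that something is new, unique, unknown or untested is made for them only; others in the source may bear on it.

Compound 1 `COC(=O)N1N=C(c2ccc(OC)cc2)CC1c1cc(OC)c(OC)c(OC)c1`: 1990 nM
Compound 2 `CCCOC(=O)N1N=C(c2ccc(OC)cc2)CC1c1cc(OC)c(OC)c(OC)c1`: 20400 nM

In a functional assay on MDA-MB-231 cells (Homo sapiens) for antiproliferative activity, read by MTT assay, with a stated time of 48 h (on this read-out higher numbers stand for weaker inhibition of growth and lower numbers for stronger inhibition of growth), compound 2 holds the higher of the two numbers. Compound 3 `CCCOC(=O)N1N=C(c2cccc(O)c2)CC1c1cc(OC)c(OC)c(OC)c1` differs from it at one place: 3-hydroxyphenyl in place of 4-methoxyphenyl on a carbon with a double bond to nitrogen. Going by the values given here, the only measured step, a 10-fold higher number from compound 1 to compound 2 (1.01 log units; beyond the scatter), was large but lies elsewhere in the structure. Among the compounds with values here, it shows that numbers here can move widely, yet no measured step covers this change. A modest, uncertain step is expected, namely a 2.0-fold lower number from compound 2 to compound 3 (0.31 log units; beyond the scatter). Compound 3 is estimated at 10000 nM, within an expected range from 2500 nM to 40000 nM.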

Compound 3, concentration for 50% growth inhibition: 10000 nM
The estimate for compound 3 equals the measured number at the digits printed; measured number inside the range.
By their numbers in this assay, from the lowest: compound 1; then compound 3; then compound 2.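

In this assay, the position on the carbon with a double bond to nitrogen also affects the number, not only the propoxycarbonyl group: 3-hydroxyphenyl in place of 4-methoxyphenyl gives a 2.0-fold lower number from compound 2 to compound 3 (0.31 log units; beyond the scatter). The entering group has 1 hydrogen-bond donor and the leaving group has 0, but no measurement offered here accounts for the step.

The compounds shown do not separate the change of substituent from the change in its ring position. Going by these compounds, an amine or a carboxylic acid at this place remains open, as does 3-hydroxyphenyl on the core of compound 1.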